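Carbonyl substituent change from compound 2 to compound 3

The source may hold more compounds than are shown below. What is called first, only, known or untested is meant among the compounds shown, and "the series" means these compounds.

For the measured compounds named here, in an ADME assay on microsomes from liver (Mus musculus) for metabolic stability, with a stated time of 10 min (a higher number here means that more of the compound is left, a lower number that less of the compound is left), compound 1 (`CC(=O)N1CC[C@@H](C(=O)N2CC[C@](c3ccc(C(OCc4c(F)cccc4F)(C(F)(F)F)C(F)(F)F)cc3)(S(=O)(=O)c3ccc(F)cc3)C2)C1`) gives 55% and compound 2 (`CC(=O)N1CCC(O)(C(=O)N2CC[C@](c3ccc(C(OCc4c(F)cccc4F)(C(F)(F)F)C(F)(F)F)cc3)(S(=O)(=O)c3ccc(F)cc3)C2)CC1`) gives 69%, the higher of the two numbers so far. Compound 3 (`O=C(N1CCOCC1)N1CC[C@](c2ccc(C(OCc3c(F)cccc3F)(C(F)(F)F)C(F)(F)F)cc2)(S(=O)(=O)c2ccc(F)cc2)C1`) has not yet been measured. It carries morpholin-4-yl in place of 1-acetyl-4-hydroxypiperidin-4-yl on a carbonyl carbon, and the carbonyl carbon's other neighbour is an amide-type nitrogen in a ring: morpholin-4-yl in place of 1-acetyl-4-hydroxypiperidin-4-yl on a carbonyl carbon.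

Going by the values given here, only one measured step bears on this change, as it also exchanges the group on a carbonyl carbon: a number 14 percentage points higher from compound 1 to compound 2 (beyond the scatter). That step is modest but beyond the scatter. A single step gives a rough size and no firm direction for a different group. A change of similar or smaller size is therefore expected, and a fall is slightly more likely than a rise, since compound 2 at 69% is the higher of the two measured compounds. The expected step is small: a number 7 percentage points lower from compound 2 to compound 3 (within the scatter). For compound 3 the estimate is 62%, with an expected range of 42% to 80%.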

Compound 3, percent of the compound remaining: 18%
Beside the measured number, compound 3's estimate is 44 percentage points above it; the whole stated range lies above it.
By their numbers in this assay, from the lowest: compound 3; then compound 1; then compound 2.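

In this assay, the group on the carbonyl carbon can move the read-out much further than the earlier pair showed: morpholin-4-yl in place of 1-acetyl-4-hydroxypiperidin-4-yl gives a number 51 percentage points lower from compound 2 to compound 3 (beyond the scatter), and morpholin-4-yl in place of 1-acetylpyrrolidin-3-yl gives a number 37 percentage points lower from compound 1 to compound 3 (beyond the scatter), both far larger than a number 14 percentage points higher from compound 1 to compound 2 (beyond the scatter). Compound 3 is the only one of the three in which the group is joined to the carbonyl carbon through a ring nitrogen, and it stands lowest of the three, with both compounds joined through a ring carbon above it. Nothing at hand explains this drop in the read-out.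

Compound 3 differs from compound 2 in several features at once (the joining atom, the ring hetero atoms, the acetyl group and the hydroxyl group), so the compounds shown do not separate their contributions. As far as these compounds go, it remains open whether a 4-acetylpiperazin-1-yl or 4-hydroxypiperidin-1-yl group, joined through nitrogen to the same carbonyl carbon, would read closer to compound 3 or to compound 2.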